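Removing the phenyl group from compound 3

The compounds below may be only part of what the source reports. "The series", "measured", "known", "first", "only" and "open" are said of these compounds alone.

Compounds measured in an in vitro assay on SH-EP1 cells for displacement of a labelled ligand from Neuronal acetylcholine receptor; alpha4/beta2 (Homo sapiens); a higher number here means a weaker inhibitor, a lower number a stronger inhibitor:
compound 1 `Fc1ccc(C2=CC3CNCC(C2)C3)cn1` gives 0.4 nM
compound 2 `FC(F)(F)c1cncc(C2=CC3CNCC(C2)C3)c1` gives 0.7 nM
compound 3 `C1=C(c2ccc(-c3ccccc3)nc2)CC2CNCC1C2` gives 105 nM

Compound 3 stands highest of the three numbers in this assay; its nearest neighbour is compound 2, and the gap to compound 1 is larger still, both well beyond the scatter. The step to compound 4 `C1=C(c2cccnc2)CC2CNCC1C2` is hydrogen in place of phenyl on an aromatic carbon, on the aromatic carbon next to the ring nitrogen, para to a group of 9 heavy atoms. Among the compounds with values here, one measured step bears on it directly: a 260-fold higher number from compound 1 to compound 3 (2.42 log units; beyond the scatter). Compound 4 carries neither the fluoro of compound 1 nor the phenyl of compound 3 at that carbon, so the step from compound 3 to compound 4 undoes the change that produced the large rise, and a large fall in this assay is expected, a 110-fold lower number from compound 3 to compound 4 (2.02 log units; beyond the scatter). Compound 4 is therefore estimated at 1 nM, with a range from 0.3 nM to 4 nM, close to compound 1.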

Compound 4, inhibition constant: 0.2 nM
The estimate for compound 4 lay 5.0-fold (0.70 log units) above the measured number; measured number outside the range, below it.
By their numbers in this assay, from the lowest: compounds 4, 1 and 2 (each within the scatter of the next, the first and the last beyond it); then compound 3.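

In this assay, the large penalty belongs to the phenyl itself and not to the loss of fluoro, as the unsubstituted aromatic carbon next to the ring nitrogen gives a 530-fold lower number from compound 3 to compound 4 (2.72 log units; beyond the scatter). A group at that carbon is therefore not needed for a low number: fluoro makes no difference beyond the scatter, with a 2.0-fold lower number from compound 1 to compound 4 (0.30 log units; within the scatter), while replacing the trifluoromethyl of compound 2 by hydrogen gives a 3.5-fold lower number from compound 2 to compound 4 (0.54 log units; beyond the scatter). Nothing available explains why the phenyl costs so much at this carbon.

On these data alone, only hydrogen, fluoro and phenyl can be compared at that carbon, so it remains open how a methyl, a methoxy or an amine there would compare with them. As far as these compounds go, it is also open whether a benzyl group would carry the same penalty as the phenyl.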